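Amine swap on the side chain at the assay limit

This account rests on a few compounds, and the source may have more. Where it says the series, first, only, none or still open, it means among the compounds named here.

In a functional assay on HL60/MX2 cells (Homo sapiens) for antiproliferative activity, read by MTT assay, with a stated time of 48 h (on this read-out lower numbers stand for stronger inhibition and higher numbers for weaker inhibition), compound 1 (`CCn1c(N)c(-c2nc3ccccc3[nH]2)c2nc(C#N)c(C#N)nc21`) gives > 50000 nM as a limit of the assay. Compound 2 (`N#Cc1nc2c(-c3nc4ccccc4[nH]3)c(N)n(CCN3CCCC3)c2nc1C#N`) gives > 50000 nM as a limit too. Compound 2 therefore has no number of its own and stands only at a limit (the limit of > 50000 nM in this assay, at which 2 of the 2 values shown sit).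

Compound 3 (`CN1CCN(CCn2c(N)c(-c3nc4ccccc4[nH]3)c3nc(C#N)c(C#N)nc32)CC1`) carries 4-methylpiperazin-1-yl in place of pyrrolidin-1-yl on a saturated chain carbon, two bonds along the chain from an aromatic nitrogen. Going by the values given here, the only measured step bearing on this change is the one that brings in pyrrolidin-1-yl (a step that the two limits leave unreadable from compound 1 to compound 2) and it has no size to carry over. No step beyond the scatter is therefore expected in this assay in either direction (a number no higher from compound 2 to compound 3 (the limit leaves the size open)). Compound 3 is expected to stay near the limit, with an estimate of 50000 nM and an estimated range from 15000 nM to 100000 nM for this measurement.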

Compound 3, half-maximal inhibitory concentration: 6490 nM
For compound 3 the middle estimate is 7.7-fold (0.89 log units) above the measured one; the whole stated range lies above it.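

In this assay, going by these compounds alone, 2-(4-methylpiperazin-1-yl)ethyl gives the only value that is not a limit, with an at least 7.7-fold lower number from compound 2 to compound 3 (0.88 log units; beyond the scatter) and an at least 7.7-fold lower number from compound 1 to compound 3 (0.88 log units; beyond the scatter). The place on a saturated chain carbon, two bonds along the chain from an aromatic nitrogen, therefore responds to the group it carries, and the presence of a non-aromatic ring there is not enough on its own, as pyrrolidin-1-yl shows. Both step sizes remain open-ended and the step that brings in pyrrolidin-1-yl cannot be read, with compound 1 and compound 2 each at a limit: the limit of > 50000 nM in this assay, at which 2 of the 3 values shown sit.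

Whether the second ring nitrogen or its methyl group accounts for the lower number remains open, and morpholin-4-yl or unsubstituted piperazin-1-yl would separate the two. Also open, from the compounds shown here alone, is the effect of chain length, which a 3-(4-methylpiperazin-1-yl)propyl chain would test.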